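Aminophenyl position shift in a series held at a limit

The source may hold more compounds than are shown below. What is called first, only, known or untested is meant among the compounds shown, and "the series" means these compounds.

Values in a functional assay on MCF7 cells (Homo sapiens) for antiproliferative activity, read by MTT assay, with a stated time of 48 h (a lower number here means a stronger inhibitor, a higher number a weaker inhibitor), each one a limit:
- compound 1 `COc1cc(-c2cccc3nc(-c4cccc(Br)c4)oc23)cc(OC)c1OC` gives > 25000 nM as a limit
- compound 2 `COc1cc(-c2cccc3nc(-c4ccc(Br)cc4)oc23)cc(OC)c1OC` gives > 25000 nM as a limit
- compound 3 `COc1cc(-c2cccc3nc(-c4ccc(N)cc4)oc23)cc(OC)c1OC` gives > 25000 nM as a limit

Compound 3 gives > 25000 nM as a limit and not a number. The other two compounds stand in the same place: the limit of > 25000 nM in this assay, at which 3 of the 3 values shown sit.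

Compound 4 `COc1cc(-c2cccc3nc(-c4cccc(N)c4)oc23)cc(OC)c1OC` differs from compound 3 by one change, (3-aminophenyl in place of 4-aminophenyl on an aromatic carbon), and the two have the same atoms, joined differently.

Among the compounds with values here, three measured steps bear on this change. The closest is the bromo pair, with the same shift of position in the opposite sense: a step that the two limits leave unreadable from compound 1 to compound 2. The other two are a step that the two limits leave unreadable from compound 1 to compound 3 and a step that the two limits leave unreadable from compound 2 to compound 3. None of them gives a size. Compound 4 holds its group in the same position as compound 1. Compound 1 gives > 25000 nM as a limit.

No step beyond the scatter is therefore expected in this assay, and no direction can be given. The expected size is a number no higher from compound 3 to compound 4 (the limit leaves the size open) as estimated. Compound 4 is estimated at 25000 nM, with an expected range from 10000 nM to 40000 nM.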

Compound 4, half-maximal inhibitory concentration: > 25000 nM
Compound 4: only a limit was reported; the forecaster's own chance of this, stated with the estimate: 85%; the middle value sits exactly at the limit.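

In this assay compound 4 gives > 25000 nM, a limit and not a number. No new step can be read between compound 4 and compound 1, compound 2 or compound 3: the limit of > 25000 nM in this assay, at which 4 of the 4 values shown sit.

The compounds shown leave open whether 3-aminophenyl and 4-aminophenyl differ at all in this assay.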